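A few compounds are considered here, and "the series" means these few. Any claim that something is new, unique, unknown or untested is made for them only; others in the source may bear on it.

Compound 3 `COc1nc(N)nc2c1c(-c1ccco1)cn2[C@@H]1O[C@H](CO)[C@@H](O)[C@H]1O` stands at the edge of what a functional assay on K562 cells (Homo sapiens), read by MTT assay, with a stated time of 72 h (a higher number here means a weaker inhibitor, a lower number a stronger inhibitor), can report: in this assay compound 3 gives > 20000 nM, which is a limit of the assay and not a number. Compound 2 `COc1ncnc2c1c(-c1ccccc1)cn2[C@@H]1O[C@H](CO)[C@@H](O)[C@H]1O` sits at the same edge: in this assay compound 2 gives > 20000 nM, again a limit. Among the compounds with values here, the only compound with a measured number is compound 1 `COc1ncnc2c1c(-c1ccsc1)cn2[C@@H]1O[C@H](CO)[C@@H](O)[C@H]1O`, which in this assay gives 3450 nM. Two of the three values therefore rest at the limit of > 20000 nM in this assay, at which 2 of the 3 values shown sit, so compound 3 can be placed only as no stronger than the limit, with no number of its own.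

The change to compound 4 `COc1ncnc2c1c(-c1ccco1)cn2[C@@H]1O[C@H](CO)[C@@H](O)[C@H]1O` is hydrogen in place of amino on an aromatic carbon. No measured step removes or adds an amino group, so none of the shown steps speaks to this change directly. Within the data shown here, the one measured step, an at least 5.7-fold higher number from compound 1 to compound 2 (0.76 log units; beyond the scatter), concerns the aryl group and shows that a swap there can carry a compound past the limit. Compound 4 carries the furan-2-yl of compound 3 and otherwise matches the core of compound 1, so a step of an at least 2.2-fold lower number from compound 3 to compound 4 (0.34 log units; beyond the scatter) is expected, meaning a number below the limit but well above that of compound 1. Compound 4 is estimated at 9000 nM, with a range from 2500 nM to 25000 nM.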

Compound 4, half-maximal inhibitory concentration: 380 nM
For compound 4 the middle estimate is 24-fold (1.37 log units) above the measured one; the whole stated range lies above it.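

Swapping the amino group on the aromatic carbon between two ring nitrogen atoms for hydrogen, with furan-2-yl held in place, produces an at least 52-fold lower number from compound 3 to compound 4 (1.72 log units; beyond the scatter) in this assay, so this position strongly affects the read-out, which no earlier step could show. With hydrogen at this position, the aryl group also matters, as there is an at least 52-fold lower number from compound 2 to compound 4 (1.72 log units; beyond the scatter) and also a 9.1-fold lower number from compound 1 to compound 4 (0.96 log units; beyond the scatter), which makes compound 4 the strongest inhibitor of the four compounds shown. The values of compound 2 and compound 3 are limits and not numbers, so the steps that start from them give only the smallest possible size of each change: the limit of > 20000 nM in this assay, at which 2 of the 4 values shown sit.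

From the compounds shown here alone, the amino group appears here only with furan-2-yl, so it remains open whether swapping it for hydrogen would have a similar effect with thiophen-3-yl or phenyl in place. Going by these compounds, it is also open how a methyl group, a chlorine atom or a dimethylamino group on this same aromatic carbon would compare with hydrogen and amino.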